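The compounds below may be only part of what the source reports. "The series", "measured", "known", "first", "only" and "open" are said of these compounds alone.

Measured compounds:
- compound 1, `COc1cc(OC)cc(-c2cc3cc(OC)cc(OC)c3oc2=O)c1`: > 100000 nM in a functional assay on aorta with Alpha-1D adrenergic receptor (Rattus norvegicus) as the target; on this read-out higher numbers stand for weaker inhibition and lower numbers for stronger inhibition
- compound 2, `O=c1oc2c(O)cc(O)cc2cc1-c1cc(O)cc(O)c1`: 95500 nM in this assay

Compound 1 gives only a limit of the assay in this assay, not a number. For the measured compounds named here, compound 2 is therefore the only compound of the pair with a measured number, and that number places it among weak inhibitors; the other value shown is the limit (the limit of > 100000 nM in this assay, at which 1 of the 2 values shown sits). Going by the values given here, with one number and one limit there is no measured step between compounds to lean on.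

Compound 3, `O=c1oc2ccc(O)cc2cc1-c1cc(O)cc(O)c1`, is not yet measured in this assay. It differs from compound 2 by hydrogen in place of hydroxy on an aromatic carbon. The shared core of compound 2 and compound 3 is otherwise unchanged. Since compound 2 already sits close to the limit at which compound 1 is reported, a further loss of a hydroxy group is expected to leave the read-out near that edge, with a step from compound 2 to compound 3 of a 1.3-fold higher number from compound 2 to compound 3 (0.10 log units; within the scatter) expected, within or only just beyond the scatter. Compound 3 is estimated at 120000 nM in this assay, with a range from 50000 nM to 300000 nM, and a real chance that only a limit is reported.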

Compound 3, half-maximal inhibitory concentration: 10600 nM
Compound 3: the middle estimate sits 11-fold (1.05 log units) above what was measured, outside the stated range (below it).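

Hydrogen in place of hydroxy on this aromatic carbon, ortho to a fused ring and meta to a hydroxy group, gives a 9.0-fold lower number from compound 2 to compound 3 (0.95 log units; beyond the scatter) in this assay, a change towards stronger inhibition. For the compounds shown here, in this pair the hydroxy group at this place is therefore not required for the read-out, and its removal is favourable, with compound 3 at 10600 nM giving the series its lowest number so far. Compound 1 remains the only compound reported as a limit, which is not a number, and the result now shows that this core can read clearly away from that edge: the limit of > 100000 nM in this assay, at which 1 of the 3 values shown sits.

From the compounds shown here alone, whether an amine or a fluorine atom on this aromatic carbon would read like hydrogen or like hydroxy remains open, so the step cannot yet be assigned to the loss of the hydroxy group as such rather than to the presence of hydrogen. Going by these compounds alone, also open is whether the same change repeats at the other hydroxy-bearing carbons of the shared core, since this single pair gives only one step at one place.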